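Cyclohexylamino to butylamino on the enaminone series

The source may hold more compounds than are shown below. What is called first, only, known or untested is meant among the compounds shown, and "the series" means these compounds.

Two compounds of the series carry a measurement in a functional assay on EA.hy 926 cells (Homo sapiens), read by fluorescence, tested at 1 uM; a higher number here means a stronger effect of the compound at the concentration tested, a lower number a weaker effect. Compound 1 `CCC(C)NC(=C\C(=O)/C=C/c1ccc(O)c(OC)c1)/C=C/c1ccc(O)c(OC)c1` gives 85% in this assay, and compound 2 `COc1cc(/C=C/C(=O)/C=C(/C=C/c2ccc(O)c(OC)c2)NC2CCCCC2)ccc1O` gives 91%. Among the compounds with values here, the single step between them, cyclohexyl in place of sec-butyl on an amine nitrogen, reads a number 6 percentage points higher from compound 1 to compound 2 (within the scatter), so compound 2 stands together with compound 1 inside the usual scatter of this assay, and no separation of the two can be claimed.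

Compound 3 `CCCCNC(=C\C(=O)/C=C/c1ccc(O)c(OC)c1)/C=C/c1ccc(O)c(OC)c1` is not yet measured. It differs from compound 2 as follows: butyl in place of cyclohexyl on an amine nitrogen. Within the data shown here, the only measured step that bears on the amine substituent is the one from compound 1 to compound 2, which stayed within the scatter; that step swapped a branched four-carbon chain for the six-membered ring, while the present change goes back from the ring to a straight chain. Nothing beyond the scatter has been seen on this position, so no step beyond the scatter is expected here either, with at most a slight drift downward toward the reading of compound 1. The expected step is a number 4 percentage points lower from compound 2 to compound 3 (within the scatter), and compound 3 is estimated at 87%, within a range from 76% to 95% in this assay.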

Compound 3, a percentage reported as activity, at one concentration (the size of the read-out at that concentration, not a potency): 110%
Compound 3: middle estimate off by 23 percentage points, on the low side, and the stated range ends below it.
By their numbers in this assay, from the lowest: compounds 1 and 2 (each within the scatter of the next); then compound 3.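

The amine nitrogen, which had shown no separation so far, now does in this assay: butyl in place of cyclohexyl reads a number 19 percentage points higher from compound 2 to compound 3 (beyond the scatter), and butyl in place of sec-butyl reads a number 25 percentage points higher from compound 1 to compound 3 (beyond the scatter). The cyclohexyl and sec-butyl compounds remain within the scatter of each other, while the unbranched butyl of compound 3 stands apart from both and gives the highest reading of the three. This position can therefore move the read-out, and among these three compounds the separation falls between the straight chain on one side and the ring and branched chain on the other, although nothing available gives a reason for the gap.

The compounds shown leave open whether this higher reading belongs to butyl alone or extends to a shorter chain such as propyl or a longer chain such as hexyl. From the compounds shown here alone, it is also open whether a straight chain ending in a hydroxyl group or a carboxylic acid would stay level with compound 3 at 110% in this assay.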